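This account rests on a few compounds, and the source may have more. Where it says the series, first, only, none or still open, it means among the compounds named here.

Working notes on the series. Compound 1 `C=C1C(=O)[C@]23C[C@@]1(F)CC[C@H]2[C@@]12C=CC(=O)[C@](C)(C(=O)O1)[C@H]2[C@@H]3C(=O)OC` gives 4100 nM in a functional assay on MKN-28 cells (Homo sapiens) for cytotoxicity, read by MTT assay; on this read-out higher numbers stand for weaker inhibition and lower numbers for stronger inhibition. Compound 2 `C=C1C(=O)[C@]23C[C@@]1(F)CC[C@H]2[C@@]12C=CC(=O)[C@](C)(C(=O)O1)[C@H]2[C@@H]3C(=O)OCc1ccccc1` differs by phenyl in place of hydrogen on a saturated chain carbon bound to an oxygen next to a carbonyl group and gives 9800 nM, a step of a 2.4-fold higher number from compound 1 to compound 2 (0.38 log units; beyond the scatter). Compound 3 `C=C1C(=O)[C@]23C[C@@]1(OCC)CC[C@H]2[C@@]12C=CC(=O)[C@](C)(C(=O)O1)[C@H]2[C@@H]3C(=O)OC` differs from compound 1 by ethoxy in place of fluoro on a saturated ring carbon; compound 3 gives 82700 nM, and the step was a 20-fold higher number from compound 1 to compound 3 (1.30 log units; beyond the scatter), leaving compound 3 with the highest number of the three measured.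

Compound 4 `C=C1C(=O)[C@]23C[C@@]1(OCC)CC[C@H]2[C@@]12C=CC(=O)[C@](C)(C(=O)O1)[C@H]2[C@@H]3C(=O)OCc1ccccc1` is not yet measured. It differs from compound 3 by phenyl in place of hydrogen on a saturated chain carbon bound to an oxygen next to a carbonyl group, the same change as that from compound 1 to compound 2, at the same place; the two cores differ by ethoxy in place of fluoro on a saturated ring carbon. Among the compounds with values here, for compound 4 a step of a 2.4-fold higher number from compound 3 to compound 4 (0.38 log units; beyond the scatter) is expected in this assay, resting on the single earlier step of a 2.4-fold higher number from compound 1 to compound 2 (0.38 log units; beyond the scatter). Compound 4 is accordingly estimated at 200000 nM, with a range from 70000 nM to 600000 nM.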

Compound 4, half-maximal inhibitory concentration: 16500 nM
Compound 4: the middle estimate sits 12-fold (1.08 log units) above what was measured, outside the stated range (below it).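

In this assay, the change from methoxycarbonyl to benzyloxycarbonyl does not carry over from the core of compound 1 to the core of compound 3, where it gives a 5.0-fold lower number from compound 3 to compound 4 (0.70 log units; beyond the scatter), in the opposite direction to the earlier step: the same change on two cores in this assay, a 2.4-fold higher number (0.38 log units; beyond the scatter) from compound 1 to compound 2 and a 5.0-fold lower number (0.70 log units; beyond the scatter) from compound 3 to compound 4, 12-fold (1.08 log units) apart, beyond the scatter of two such steps. Ethoxy in place of fluoro likewise depends on the ester present, giving only a 1.7-fold higher number from compound 2 to compound 4 (0.23 log units; within the scatter) with benzyloxycarbonyl, a step within the scatter: the same change on two cores in this assay, a 20-fold higher number (1.30 log units; beyond the scatter) from compound 1 to compound 3 and a 1.7-fold higher number (0.23 log units; within the scatter) from compound 2 to compound 4, 12-fold (1.08 log units) apart, beyond the scatter of two such steps. The two changes are therefore not additive across these four compounds, but the data do not show why, or whether this holds beyond them.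

Going by these compounds, it remains open how a carboxylic acid in place of the ester would read on either core. The same applies to an amine or a longer chain in place of ethoxy.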